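One Double Bond Redrawn From Z to E

The source may hold more compounds than are shown below. What is called first, only, known or untested is meant among the compounds shown, and "the series" means these compounds.

- compound 1 `COc1cc(/C=C/Cc2cc(O)c3cc(C)sc3c2)cc(OC)c1OC` measures 840 nM here
- compound 2 `COc1cc(/C=C\Cc2cc(O)c3cc(-c4ccccc4)sc3c2)cc(OC)c1OC` measures 23000 nM here

In a functional assay on BMEC cells (Bos taurus) for antiproliferative activity (on this read-out higher numbers stand for weaker inhibition and lower numbers for stronger inhibition), compound 2 gives 23000 nM as the higher of the two numbers, and the gap to compound 1 at 840 nM lies beyond the usual scatter of repeats. The unmeasured compound 3 `COc1cc(/C=C/Cc2cc(O)c3cc(-c4ccccc4)sc3c2)cc(OC)c1OC` is a close relative of compound 2. The change is this: the two compounds have the same atoms and bonds and differ only in configuration as drawn: 1 of 1 stereo elements differ; a double bond is drawn Z in compound 2 and E in compound 3. Compound 1 also has its double bond drawn E, but it carries a different group on the shared core, so it is only a loose guide. Its value of 840 nM for compound 1 hints that an E double bond can go with a much lower number. The estimated step of a 2.9-fold lower number from compound 2 to compound 3 (0.46 log units; beyond the scatter) is therefore a moderate fall towards stronger inhibition, though no change beyond the scatter remains possible. Compound 3 is expected at 8000 nM, with an estimated range from 1500 nM to 35000 nM as the likely span.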

Compound 3, half-maximal inhibitory concentration: 38000 nM
The estimate for compound 3 lay 4.8-fold (0.68 log units) below the measured number; the measured number lies above the stated range.
By their numbers in this assay, from the lowest: compound 1; then compounds 2 and 3 (each within the scatter of the next).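

In this assay, redrawing the double bond from Z to E gives a 1.7-fold higher number from compound 2 to compound 3 (0.22 log units; within the scatter) and so does not separate these two compounds, at least with phenyl on the shared core. The large gap goes instead with the other change, phenyl in place of methyl on an aromatic carbon, which gives a 45-fold higher number from compound 1 to compound 3 (1.66 log units; beyond the scatter) with the double bond drawn E on both sides. The comparison of the two phenyl compounds is a clean one, with a single difference to consider: the fact that compounds 2 and 3 differ only in the configuration as drawn.

Going by these compounds, whether the double bond matters more when methyl is the group on the core stays open, as only an E form carries methyl here. Also open, on these data alone, is how an amine or a carboxylic acid in that same place would compare with methyl and phenyl.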